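Isopropylsulfamoyl Analogue Weighed Against Its Sulfone Neighbour

The source may report more compounds than this note shows. Statements on the series, on what has been measured and on what is new or still open speak of the compounds shown alone.

Three compounds share one core and differ only in the group on the aromatic carbon. Compound 1 `CCN(CC)C(=O)c1ccc(S(=O)(=O)N2CCC[C@@H](C(=O)N3CCC(F)(F)CC3)C2)cc1` carries a diethylcarbamoyl group, compound 2 `CN(C)S(=O)(=O)c1ccc(S(=O)(=O)N2CCC[C@@H](C(=O)N3CCC(F)(F)CC3)C2)cc1` a dimethylsulfamoyl group and compound 3 `CC(C)CS(=O)(=O)c1ccc(S(=O)(=O)N2CCC[C@@H](C(=O)N3CCC(F)(F)CC3)C2)cc1` an isobutylsulfonyl group. In a functional assay on BXPC-3 cells (Homo sapiens) for inhibition, read by MTT assay, with a stated time of 7 days (on this read-out higher numbers stand for weaker inhibition and lower numbers for stronger inhibition), compound 1 gives 240 nM. Compound 2 gives 560 nM. Compound 3 gives 311 nM. Among these three numbers compound 3 holds the second highest place, yet it is separated from its neighbours only by a 1.3-fold higher number from compound 1 to compound 3 (0.11 log units; within the scatter) and by a 1.8-fold lower number from compound 2 to compound 3 (0.26 log units; within the scatter), so it cannot be ranked against either of them. The only gap beyond the scatter is a 2.3-fold higher number from compound 1 to compound 2 (0.37 log units; beyond the scatter).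

Compound 4 `CC(C)NS(=O)(=O)c1ccc(S(=O)(=O)N2CCC[C@@H](C(=O)N3CCC(F)(F)CC3)C2)cc1` arises from compound 3 by one change: isopropylamino in place of isobutyl on a sulfonyl sulfur. The step that bears on this is a 1.8-fold lower number from compound 2 to compound 3 (0.26 log units; within the scatter), where the sulfonyl sulfur swapped an amino substituent for an alkyl one with little effect. Compound 4 reverses that swap while keeping a similarly sized isopropyl chain, so compound 4 is expected to show a 1.3-fold higher number from compound 3 to compound 4 (0.11 log units; within the scatter), a step that stays within the scatter, if anything towards a slightly higher number. Compound 4 is therefore estimated at 400 nM, with a range from 200 nM to 800 nM.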

Compound 4, half-maximal inhibitory concentration: 470 nM
For compound 4 the middle estimate is 1.2-fold (0.07 log units) below the measured one, and the stated range covers the measured number.
By their numbers in this assay, from the lowest: compounds 1, 3, 4 and 2 (each within the scatter of the next, the first and the last beyond it).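

In this assay the change on the sulfonyl sulfur, which brings in isopropylamino with its hydrogen-bond donor in place of isobutyl at an equal heavy-atom count, gives a 1.5-fold higher number from compound 3 to compound 4 (0.18 log units; within the scatter) and so leaves no readable effect at this position. The amino groups do not separate either: a 1.2-fold lower number from compound 2 to compound 4 (0.08 log units; within the scatter) means that isopropylamino and dimethylamino on this sulfur cannot be told apart, while a 2.0-fold higher number from compound 1 to compound 4 (0.29 log units; within the scatter) keeps isopropylsulfamoyl within the scatter of diethylcarbamoyl, so the gap beyond the scatter seen for compound 2 against compound 1 does not extend to compound 4, and a sulfamoyl group as such is not set apart from the diethylcarbamoyl group. Nothing measured here speaks to why these numbers sit as they do.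

Going by these compounds, it stays open whether an unsubstituted amino group, a morpholine or a longer alkyl chain on the sulfonyl sulfur would move the number beyond the scatter of these neighbours. On these data alone, it also stays open whether a carboxylic acid on the aromatic carbon, in place of the whole group, would give a number clearly apart from compound 1.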